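Swapping Chloro for Methoxy in a Cytotoxicity Series

The source may hold more compounds than are shown below. What is called first, only, known or untested is meant among the compounds shown, and "the series" means these compounds.

Compound 1 `Clc1ccc(-c2csc(N/N=C/c3ccc(-n4ccnc4)cc3)n2)cc1` gives 32.1% in an ADME assay on THP-1 cells (Homo sapiens) for cytotoxicity, read by MTT assay, tested at 50 ug/mL; on this read-out lower numbers stand for less inhibition and higher numbers for more inhibition at the one concentration tested (going by the name of the read-out).
Compound 2 `Cc1ccc(-c2csc(N/N=C/c3ccc(-n4ccnc4)cc3)n2)cc1` gives 36%.
Compound 3 `Clc1ccc(-c2csc(N/N=C/c3ccc(-n4cncn4)cc3)n2)cc1` gives 28.4%.

Compound 3 shows the smallest of the three numbers, yet its gap to compound 1 and its gap to compound 2 are both within the scatter, so the three measured compounds cannot be told apart. Compound 4 `COc1ccc(-c2csc(N/N=C/c3ccc(-n4cncn4)cc3)n2)cc1` differs from compound 3 by methoxy in place of chloro on an aromatic carbon: a chloro leaves and a methoxy enters on the same aromatic carbon. Within the data shown here, the one measured step that bears on this, replacing chloro at that carbon, is a number 3.9 percentage points higher from compound 1 to compound 2 (within the scatter), a change within the scatter. No step beyond the scatter is therefore expected in this assay for compound 4, and the estimated step is a number 1.6 percentage points higher from compound 3 to compound 4 (within the scatter). Compound 4 is expected to give about 30%, between 18% and 42%.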

Compound 4, a percentage reported as inhibition, at one concentration (the size of the read-out at that concentration, not a potency): 23%
Compound 4: the middle estimate sits 7 percentage points above what was measured, within the range that was stated.
By their numbers in this assay, from the lowest: compounds 4, 3, 1 and 2 (each within the scatter of the next, the first and the last beyond it).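

Methoxy in place of chloro on this carbon gives a number 5.4 percentage points lower from compound 3 to compound 4 (within the scatter) in this assay and the methyl swap gives a number 3.9 percentage points higher from compound 1 to compound 2 (within the scatter) on the same carbon. This position, para to a large group, has now taken two different replacements for chloro, one with a hydrogen-bond acceptor, without a step beyond the scatter. Nothing measured here explains these small steps.

Going by these compounds, whether an amine or a carboxylic acid on this carbon would also stay within the scatter remains open. So does whether methoxy would behave alike with 1H-imidazol-1-yl in place of 1H-1,2,4-triazol-1-yl.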